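Seeking a Measurable Value Beyond the Assay Limit

A few compounds are considered here, and "the series" means these few. Any claim that something is new, unique, unknown or untested is made for them only; others in the source may bear on it.

Compound 1 `CCCCn1ccnc1-c1cc(OC)c(OC)c(OC)c1`: > 100000 nM (a limit)
Compound 2 `COc1cc(-c2nccn2S(=O)(=O)c2ccccc2)cc(OC)c1OC`: > 100000 nM (a limit)

In a functional assay on T47D cells (Homo sapiens) for antiproliferative activity, read by MTT assay, with a stated time of 72 h (a higher number here means a weaker inhibitor, a lower number a stronger inhibitor), compound 1 gives > 100000 nM, which is a limit and not a number. Compound 2 gives > 100000 nM, which is also a limit. Among the compounds with values here, compound 1 thus stands with the only other measured compound: the data show (the limit of > 100000 nM in this assay, at which 2 of the 2 values shown sit).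

Compound 3 `COc1cc(-c2nccn2-c2ccc(Br)cc2)cc(OC)c1OC` has 4-bromophenyl in place of butyl on an aromatic nitrogen. Within the data shown here, no measured step shows what such a change does, so any expectation here is uncertain. In this assay, a moderate move towards stronger inhibition is expected, although compound 3 could also remain at the limit. The expected step is an at least 3.3-fold lower number from compound 1 to compound 3 (0.52 log units; beyond the scatter). For compound 3, the estimated value is 30000 nM, with an expected range from 3000 nM to 100000 nM.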

Compound 3, half-maximal inhibitory concentration: 24600 nM
For compound 3 the middle estimate is 1.2-fold (0.09 log units) above the measured one; the range from low to high includes it.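

In this assay, compound 3 is the only compound shown with a measurable value, so the group on this aromatic nitrogen can bring the shared core within the range the assay can read. Compound 1 gives > 100000 nM, which is a limit. Replacing butyl with 4-bromophenyl therefore gives an at least 4.0-fold lower number from compound 1 to compound 3 (0.60 log units; beyond the scatter), and the true size of this step may be larger than the printed bound.

As far as these compounds go, whether the ring or the bromine carries this gain stays open, and a plain phenyl or a 4-chlorophenyl on the same nitrogen would help to separate the two. With a single measured value, no trend can yet be drawn, and most of the set still gives no number: the limit of > 100000 nM in this assay, at which 2 of the 3 values shown sit.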